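Phenyl for Cyanobutyl on a Fused Diamino Core

The source may report more compounds than this note shows. Statements on the series, on what has been measured and on what is new or still open speak of the compounds shown alone.

Measured compounds:
compound 1, `Cc1ncc2c(N)c(C#N)c(N)nc2n1`, 783000 nM
compound 2, `CC(C)(C)c1nc(CCCCC#N)c2c(N)c(C#N)c(N)nc2n1`, 16000 nM

Of the compounds shown here, two sharing a fused diamino nitrile core have been measured in a physicochemical assay for solubility, in phosphate buffer, with a stated time of 18 h; a lower number here means a less soluble compound, a higher number a more soluble compound. Compound 1, the smaller of the two, gives 783000 nM. Compound 2 carries a tert-butyl group and a 4-cyanobutyl chain and gives 16000 nM, the lower of the two numbers; the gap to compound 1 is well beyond the usual scatter of such measurements, so compound 2 stands as the less soluble of the pair.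

Compound 3, `CC(C)(C)c1nc(-c2ccccc2)c2c(N)c(C#N)c(N)nc2n1`, is not yet measured. It differs from compound 2 in one place: phenyl in place of 4-cyanobutyl on an aromatic carbon. The 4-cyanobutyl chain, with its one hydrogen-bond acceptor, is replaced by phenyl, which carries none.

Among the measured compounds shown here, with no measured step of this kind to lean on, the size of the change is uncertain. Compound 3 is expected to sit somewhat below compound 2 in this assay, a step of a 2.0-fold lower number from compound 2 to compound 3 (0.30 log units; within the scatter) that may well fall within the scatter. The estimate for compound 3 is 8000 nM, with a range from 2000 nM to 40000 nM.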

Compound 3, solubility: 4000 nM
Estimate against measurement, compound 3: 2.0-fold (0.30 log units) above; the measured number falls inside the stated range.
By their numbers in this assay, from the lowest: compound 3; then compound 2; then compound 1.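

Among the compounds shown here, the comparison of compound 2 with compound 3 gives the first measured step at a single position: in this assay, phenyl in place of 4-cyanobutyl on an aromatic carbon next to the ring nitrogen gives a 4.0-fold lower number from compound 2 to compound 3 (0.60 log units; beyond the scatter), a change beyond the usual scatter. The number at this position therefore responds to the group that stands there, with the tert-butyl group and the shared core held constant. The two groups have the same count of heavy atoms, so the step comes with no change in that count, although nothing available explains the size or direction of the step.

This single pair cannot show whether the step reflects the arrival of phenyl, the loss of the nitrile-bearing chain, or both. From the compounds shown here alone, how a shorter alkyl chain, a pyridine ring or an amine at this position would read in this assay remains open, as does whether the step would hold with another group in place of the tert-butyl group.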